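Swapping a Trifluoromethylphenyl Group for Oxolane in a Fused Core

The source may report more compounds than this note shows. Statements on the series, on what has been measured and on what is new or still open speak of the compounds shown alone.

Compound 2 `FC(F)(F)c1ccc(Nc2cc3[nH]c(-c4cccc(C(F)(F)F)c4)nc3cn2)nc1` holds the higher of the two measured numbers in an ADME assay on microsomes from liver (Homo sapiens) for metabolic stability, read by LC-MS, with a stated time of 30 min, tested at 0.1 uM; on this read-out higher numbers stand for a more stable compound and lower numbers for a less stable compound: compound 2 gives 90%, while compound 1 `FC(F)(F)c1cccc(-c2nc3cnc(Nc4cnccn4)cc3[nH]2)c1` gives 43%. Within the data shown here, the only measured step, a number 47 percentage points higher from compound 1 to compound 2 (beyond the scatter), concerns 5-(trifluoromethyl)pyridin-2-yl in place of pyrazin-2-yl on a nitrogen on an aromatic ring, and so it touches a different part of the molecule than the change considered next.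

Compound 3 `FC(F)(F)c1ccc(Nc2cc3[nH]c(C4CCOC4)nc3cn2)nc1` differs from compound 2 at another site: oxolan-3-yl in place of 3-(trifluoromethyl)phenyl on an aromatic carbon. The exchange sits on an aromatic carbon of a five-membered aromatic ring with 2 nitrogen, part of a fused or bridged system of two rings, between two ring nitrogen atoms. Among the measured compounds shown here, no measured step bears on this exchange, as the single step seen so far leaves this position untouched. The expectation for compound 3 therefore rests on compound 2 alone, with no guidance on direction. The step of a number 25 percentage points lower from compound 2 to compound 3 (beyond the scatter) is expected only with wide uncertainty. In this assay compound 3 is estimated to give 65%, within a range from 30% to 95%.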

Compound 3, percent of the compound remaining: 81%
Estimate against measurement, compound 3: 16 percentage points below; low and high end bracket the measured number.
By their numbers in this assay, from the lowest: compound 1; then compounds 3 and 2 (each within the scatter of the next).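

Among these compounds, at the aromatic carbon between two ring nitrogen atoms, the earlier compounds gave no reading, and the exchange of 3-(trifluoromethyl)phenyl for oxolan-3-yl now gives a number 9 percentage points lower from compound 2 to compound 3 (within the scatter) in this assay. With 5-(trifluoromethyl)pyridin-2-yl kept on the nitrogen, this read-out therefore does not separate a six-membered aromatic ring of carbon only, carrying trifluoromethyl, from a five-membered non-aromatic ring with 1 hetero atom. Nothing measured on these compounds gives a reason for this outcome.

It remains open whether the same exchange would hold with pyrazin-2-yl on the nitrogen, as compound 1, the only compound shown with that group, carries 3-(trifluoromethyl)phenyl and gives 43%. Also open, as far as these compounds go, are how this position would respond to an amine, a carboxylic acid or a longer alkyl chain, and whether the ring oxygen of oxolan-3-yl matters, a question that a cyclopentyl group in the same place could address.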